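The compounds below may be only part of what the source reports. "The series", "measured", "known", "first", "only" and "open" are said of these compounds alone.

Measured in a functional assay on CHO cells for agonist activity at Alpha-2C adrenergic receptor (Homo sapiens); a higher number here means a larger maximal response, a lower number a smaller maximal response:

Compound 1 `COc1ccc(S(C)(=O)=O)c(NCC2=NCCN2)c1`: 49%
Compound 2 `CSc1ccc(C)cc1NCC1=NCCN1`: 81%
Compound 3 `CS(=O)(=O)c1ccc(F)cc1NCC1=NCCN1`: 91%

Among these three numbers compound 3 stands highest, though its gap to compound 2 lies within the usual scatter, while compound 1 sits far below it. Within the data shown here, the only single-point step available is the one from compound 1 to compound 3, fluoro in place of methoxy on an aromatic carbon, which gave a number 42 percentage points higher from compound 1 to compound 3 (beyond the scatter).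

Compound 4 `Cc1ccc(S(C)(=O)=O)c(NCC2=NCCN2)c1` is not yet measured. It differs from compound 3 in one place: methyl in place of fluoro on an aromatic carbon. Among the measured compounds shown here, no measured step swaps fluoro for methyl, so the step from compound 1 to compound 3 bears on it only loosely, by showing that a change at this position can move the read-out a long way. Compound 2 also carries a methyl at this position and gives 81%, yet it differs from compound 4 elsewhere too, so it offers only a hint. A small step, if any, is expected, so compound 4 is estimated at 83% (range 66% to 98%), a change of a number 8 percentage points lower from compound 3 to compound 4 (within the scatter) that is expected to stay within the scatter.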

Compound 4, largest response reached (reported as maximum), in percent of the reference or control that the assay uses: 76%
Compound 4: the middle estimate sits 7 percentage points above what was measured, and the stated range covers the measured number.
By their numbers in this assay, from the lowest: compound 1; then compounds 4, 2 and 3 (each within the scatter of the next, the first and the last beyond it).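

On the shared core, at the carbon para to a methylsulfonyl group, this assay now separates three groups: methyl in place of fluoro gives a number 15 percentage points lower from compound 3 to compound 4 (beyond the scatter) while methyl in place of methoxy gives a number 27 percentage points higher from compound 1 to compound 4 (beyond the scatter) and so methyl takes a middle place, with both steps beyond the scatter. With methyl kept at this carbon, the other single change, methylsulfonyl in place of methylsulfanyl, gives a number 5 percentage points lower from compound 2 to compound 4 (within the scatter) and so does not separate those two groups in this read-out. Nothing measured here accounts for these differences.

From the compounds shown here alone, whether an amine, a carboxylic acid or a longer chain at this carbon would give a response nearer that of fluoro or that of methoxy remains open. Also open is whether fluoro and methoxy would keep their order with methylsulfanyl in place of methylsulfonyl; only methyl is shown with both groups.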